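The source may report more compounds than this note shows. Statements on the series, on what has been measured and on what is new or still open speak of the compounds shown alone.

Measured compounds in an assay on a protein complex for binding affinity to Neuronal acetylcholine receptor; alpha3/beta2 (Homo sapiens); on this read-out lower numbers stand for stronger inhibition and higher numbers for weaker inhibition:
compound 1 `CN1CCC[C@H]1COc1cncc(C#CCCCCF)c1` gives 14 nM
compound 2 `CN1CCC[C@H]1COc1cncc(C#CC(C)(C)O)c1` gives 23 nM
compound 3 `C#Cc1cncc(OC[C@@H]2CCCN2C)c1` gives 8.2 nM

Compound 3 carries the lowest of the three numbers in this assay . The step of a 1.7-fold lower number from compound 1 to compound 3 (0.23 log units; within the scatter) stays within the scatter, whereas the step of a 2.8-fold lower number from compound 2 to compound 3 (0.45 log units; beyond the scatter) is modest but beyond it.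

Compound 4 `CN1CCC[C@H]1COc1cncc(C#Cc2ccccc2)c1` differs from compound 3 by phenyl in place of hydrogen on a triple-bonded carbon. The two measured steps onto that triple-bonded carbon both bear on this: removing a substituent there lowered the number slightly or not at all, so adding one is expected to raise it slightly, if at all. For the measured compounds named here, no measured compound carries an aromatic ring at that place. A small rise is therefore expected, a 1.7-fold higher number from compound 3 to compound 4 (0.23 log units; within the scatter). For compound 4 the estimated value in this assay is 14 nM, within 6 nM to 35 nM.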

Compound 4, inhibition constant: 8.6 nM
Compound 4: middle estimate off by 1.6-fold (0.21 log units), on the high side; measured number inside the range.
By their numbers in this assay, from the lowest: compounds 3, 4, 1 and 2 (each within the scatter of the next, the first and the last beyond it).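

In this assay, for the compounds shown here, the triple-bonded carbon takes an aromatic ring, which no earlier compound carried: phenyl in place of hydrogen gives a 1.0-fold higher number from compound 3 to compound 4 (0.02 log units; within the scatter) and phenyl in place of 4-fluorobutyl gives a 1.6-fold lower number from compound 1 to compound 4 (0.21 log units; within the scatter) and both steps stay within the scatter. Only 1-hydroxy-1-methylethyl stands apart, with a 2.7-fold lower number from compound 2 to compound 4 (0.43 log units; beyond the scatter) as a modest step of about the same size as a 2.8-fold lower number from compound 2 to compound 3 (0.45 log units; beyond the scatter) at this position.

From the compounds shown here alone, whether a chlorophenyl, a pyridine ring or an amine at this carbon would keep these numbers stays open. No evidence at hand accounts for the steps at this position.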